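Replacing Naphthalen-1-yl in Compound 3

A few compounds are considered here, and "the series" means these few. Any claim that something is new, unique, unknown or untested is made for them only; others in the source may bear on it.

In a functional assay on MDA-MB-231 cells (Homo sapiens) for antiproliferative activity, read by MTT assay, with a stated time of 48 h (on this read-out higher numbers stand for weaker inhibition and lower numbers for stronger inhibition), compound 1 (`C=CS(=O)(=O)N1CCN(c2ccn3ncc(-c4ccccc4)c3n2)CC1`) gives 38300 nM, compound 2 (`C=CS(=O)(=O)N1CCN(c2ncnc3sc(-c4ccc(N5CCN(C)CC5)cc4)cc23)CC1`) gives 7550 nM and compound 3 (`C=CS(=O)(=O)N1CCN(c2ncnc3sc(-c4cccc5ccccc45)cc23)CC1`) gives 23700 nM. Compound 3 thus lies within the scatter of compound 1, while its number is higher than that of compound 2, a gap beyond the scatter. Compound 4 (`C=CS(=O)(=O)N1CCN(c2ncnc3sc(-c4cc(Br)cnc4F)cc23)CC1`) carries 5-bromo-2-fluoropyridin-3-yl in place of naphthalen-1-yl on an aromatic carbon. For the measured compounds named here, no measured pair isolates this change, so the expectation starts from compound 3 at 23700 nM. No change beyond the scatter is expected in this assay, and the estimated step is a 1.2-fold lower number from compound 3 to compound 4 (0.07 log units; within the scatter). Compound 4 is expected at 20000 nM, with an estimated range of 8000 nM to 50000 nM.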

Compound 4, half-maximal inhibitory concentration: 24100 nM
Estimate against measurement, compound 4: 1.2-fold (0.08 log units) below; low and high end bracket the measured number.
By their numbers in this assay, from the lowest: compound 2; then compounds 3, 4 and 1 (each within the scatter of the next).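

Placing 5-bromo-2-fluoropyridin-3-yl instead of naphthalen-1-yl on the aromatic carbon next to the ring sulfur gives a 1.0-fold higher number from compound 3 to compound 4 (0.01 log units; within the scatter) in this assay for this pair. Although one group has two carbon-only rings and the other a single ring with a hetero atom and a hydrogen-bond acceptor, this read-out does not separate them. No evidence at hand explains this. The compounds shown leave open whether the bromine and fluorine each matter on their own. They also leave open how a morpholine or a carboxylic acid at this position would read.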